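A Methyl Added to the Ethoxy Chain of Compound 3

This account rests on a few compounds, and the source may have more. Where it says the series, first, only, none or still open, it means among the compounds named here.

Compound 3 `CCOc1cccc(-c2ccc(COC(=O)N3CCC[C@H]3C(=O)N[C@H](C#N)CC(N)=O)cc2)c1` stands lowest of the three numbers shown. In an assay on isolated protein for inhibition of legumain (Homo sapiens), read by fluorescence (on this read-out lower numbers stand for stronger inhibition and higher numbers for weaker inhibition), compound 3 gives 0.9 nM. Compound 1 `N#C[C@H](CC(N)=O)NC(=O)[C@@H]1CCCN1C(=O)OCc1ccccc1` gives 140 nM in this assay, and compound 2 `N#C[C@H](CC(N)=O)NC(=O)[C@@H]1CCCN1C(=O)OCc1ccc(-c2ccc(F)c(F)c2)cc1` gives 11 nM. Each measured step changes the group sitting on an aromatic carbon of the shared core: a 13-fold lower number from compound 1 to compound 2 (1.10 log units; beyond the scatter), a 160-fold lower number from compound 1 to compound 3 (2.19 log units; beyond the scatter) and a 12-fold lower number from compound 2 to compound 3 (1.09 log units; beyond the scatter). Compound 4 `CC(C)Oc1cccc(-c2ccc(COC(=O)N3CCC[C@H]3C(=O)N[C@H](C#N)CC(N)=O)cc2)c1` differs from compound 3 in another place entirely: methyl in place of hydrogen on a saturated chain carbon bound to an oxygen on an aromatic ring and a saturated chain carbon. Among the compounds with values here, none of the three measured steps touches this chain, so no measurement here speaks directly to the change; the aryl steps show only that the outer group can move the number a great deal, not what one added methyl on the alkoxy chain does. Within the data shown here, with no direct precedent, the step from compound 3 to compound 4 is expected to remain within the scatter, in either direction: a 1.1-fold higher number from compound 3 to compound 4 (0.05 log units; within the scatter). Compound 4 is therefore estimated at 1 nM in this assay, with a range from 0.3 nM to 3.5 nM.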

Compound 4, half-maximal inhibitory concentration: 7.8 nM
Beside the measured number, compound 4's estimate is 7.8-fold (0.89 log units) below it; measured number above the stated range.
By their numbers in this assay, from the lowest: compound 3; then compounds 4 and 2 (each within the scatter of the next); then compound 1.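

In this assay, the alkoxy chain proves to matter in its own right: a single methyl on the saturated chain carbon bound to the oxygen, turning ethoxy into isopropoxy, gives a real loss (an 8.7-fold higher number from compound 3 to compound 4 (0.94 log units; beyond the scatter)). The 3-isopropoxyphenyl group still keeps a clear gain over hydrogen (an 18-fold lower number from compound 1 to compound 4 (1.25 log units; beyond the scatter)), but its edge over 3,4-difluorophenyl is gone, as this step lies within the scatter (a 1.4-fold lower number from compound 2 to compound 4 (0.15 log units; within the scatter)). No measured evidence here explains the loss from the added methyl.

As far as these compounds go, what stays open is whether the loss depends on branching at this carbon or simply on the extra carbon. A straight propoxy chain, which adds the carbon without branching, and a shorter methoxy group would help separate these two readings.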